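The compounds below may be only part of what the source reports. "The series", "measured", "known", "first", "only" and "open" are said of these compounds alone.

Measured compounds in an assay on Cerebral cortex for displacement of a labelled ligand from Adrenergic receptor alpha-1 (Rattus norvegicus); on this read-out lower numbers stand for stronger inhibition and higher numbers for weaker inhibition:
compound 1, `CCOc1ccccc1N1CCN(CCCCn2nc(-c3ccc(C)cc3)c3ccccc3c2=O)CC1`, gives 2.23 nM
compound 2, `Cc1ccc(-c2nn(CCCCN3CCN(c4ccccc4OC(C)C)CC3)c(=O)c3ccccc23)cc1`, gives 1.07 nM
compound 3, `Cc1ccc(-c2nn(CCCCN3CCN(c4cccc(C(F)(F)F)c4)CC3)c(=O)c3ccccc23)cc1`, gives 112 nM

Compound 3 stands at the highest number of the three, that is the weakest binder here: the step from compound 1 to compound 3 is a 50-fold higher number from compound 1 to compound 3 (1.70 log units; beyond the scatter), and the step from compound 2 to compound 3 is a 100-fold higher number from compound 2 to compound 3 (2.02 log units; beyond the scatter). Both steps exchange the aryl group on the amine nitrogen in the ring, and both are large. By contrast the step of a 2.1-fold lower number from compound 1 to compound 2 (0.32 log units; beyond the scatter), which only lengthens the alkoxy group, is modest.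

Compound 4, `Cc1ccc(-c2nn(CCCCN3CCN(c4ncccn4)CC3)c(=O)c3ccccc23)cc1`, is not yet measured. It differs from compound 3 in one place: pyrimidin-2-yl in place of 3-(trifluoromethyl)phenyl on an amine nitrogen in a ring. Among the measured compounds shown here, no measured step exchanges one aryl group for a heteroaryl group at this position, so the two large steps ending at compound 3 bear on it only in showing that this position moves the number a great deal. The direction cannot be read from them. Compound 4 is therefore expected to remain in the weak range of compound 3, with a modest step of a 1.8-fold higher number from compound 3 to compound 4 (0.25 log units; within the scatter), and wide uncertainty. For compound 4 in this assay the estimate is 200 nM, within 40 nM to 1000 nM.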

Compound 4, inhibition constant: 270 nM
For compound 4 the middle estimate is 1.4-fold (0.13 log units) below the measured one, within the range that was stated.
By their numbers in this assay, from the lowest: compound 2; then compound 1; then compound 3; then compound 4.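

In this assay, among the compounds shown here, the first heteroaryl group on the amine nitrogen in a ring gives a 2.4-fold higher number from compound 3 to compound 4 (0.38 log units; beyond the scatter) and so stays close to 3-(trifluoromethyl)phenyl, which shows that the weak range at this position is not confined to a ring of carbon only. Against the two alkoxyphenyl compounds the same exchange gives a 120-fold higher number from compound 1 to compound 4 (2.08 log units; beyond the scatter) and a 250-fold higher number from compound 2 to compound 4 (2.40 log units; beyond the scatter) and makes compound 4 the weakest binder of the four, so 2-ethoxyphenyl and 2-isopropoxyphenyl now stand apart from both other groups. Pyrimidin-2-yl, with 2 hydrogen-bond acceptors, and 3-(trifluoromethyl)phenyl, with none, both give weak binding here, and no supporting data are available to explain this result.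

From the compounds shown here alone, it remains open whether the strong binding depends on the alkoxy group or on the phenyl ring, a question that unsubstituted phenyl, 2-methoxyphenyl or pyridin-2-yl on the same nitrogen could help to settle. Going by these compounds, it is also open whether the order of these aryl groups would hold with a longer chain in place of the present one.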